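Swapping Chloro for Methoxy: Expected Tolerance of Compound 3

This account rests on a few compounds, and the source may have more. Where it says the series, first, only, none or still open, it means among the compounds named here.

Compound 1 `COc1ccc(C2=NN(c3ccc(S(N)(=O)=O)cc3)C(c3cn(-c4ccccc4)nc3-c3ccccc3)C2)cc1`: 40200 nM
Compound 2 `COc1ccc(C2=NN(c3ccc(S(N)(=O)=O)cc3)C(c3cn(-c4ccccc4)nc3-c3ccc(Cl)cc3)C2)cc1`: 31300 nM

Both compounds were tested in an ADME assay on Vero cells (Chlorocebus sabaeus) for cytotoxicity, read by MTT assay, with a stated time of 72 h; a lower number here means that less compound is tolerated, a higher number that more compound is tolerated. Within the data shown here, on those two numbers compound 2 stands as the lowest, with compound 1 as its only neighbour, and the step of a 1.3-fold lower number from compound 1 to compound 2 (0.11 log units; within the scatter) is within the scatter, so the two are not distinguishable by this assay. Compound 3 `COc1ccc(C2=NN(c3ccc(S(N)(=O)=O)cc3)C(c3cn(-c4ccccc4)nc3-c3ccc(OC)cc3)C2)cc1` has not been measured. It differs from compound 2 by methoxy in place of chloro on an aromatic carbon. Among the measured compounds shown here, no measured step copies this swap; the one step available, a 1.3-fold lower number from compound 1 to compound 2 (0.11 log units; within the scatter), concerns the same group that now leaves and was within the scatter. On that basis the step of a 1.1-fold higher number from compound 2 to compound 3 (0.05 log units; within the scatter) is expected to stay within the scatter, with no clear direction. For compound 3 the estimate in this assay is 35000 nM, with a range from 15000 nM to 80000 nM.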

Compound 3, half-maximal cytotoxic concentration: 104000 nM
The estimate for compound 3 lay 3.0-fold (0.47 log units) below the measured number; the whole stated range lies below it.
By their numbers in this assay, from the lowest: compounds 2 and 1 (each within the scatter of the next); then compound 3.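

In this assay this place on the ring, para to a large group, proves not to be indifferent: methoxy in place of chloro gives a 3.3-fold higher number from compound 2 to compound 3 (0.52 log units; beyond the scatter) and methoxy in place of hydrogen gives a 2.6-fold higher number from compound 1 to compound 3 (0.41 log units; beyond the scatter) in the same direction. Chloro and hydrogen could not be told apart here, so the earlier pair gave no sign that a change at this place could move the number, whereas methoxy stands clear of both, with more compound tolerated. Nothing available bears on what lies behind this shift.

The compounds shown leave open whether the rise belongs to methoxy alone or would also appear with a hydroxyl, an amine or a longer chain such as ethoxy at the same place. They also leave open whether the 4-chlorophenyl to 4-methoxyphenyl change would give a similar step on a different core.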